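A Trimethylbenzyl Variant of a Cytotoxic Lead

A few compounds are considered here, and "the series" means these few. Any claim that something is new, unique, unknown or untested is made for them only; others in the source may bear on it.

Measured compounds:
compound 1, `COc1cccc(CSc2nnc([C@@H](C)c3ccc4cc(OC)ccc4c3)n2-c2ccc(F)cc2)c1` — 19200 nM
compound 2, `COc1ccc2cc([C@H](C)c3nnc(SCc4ccc(C)cc4)n3-c3ccc(F)cc3)ccc2c1` — 44300 nM

In a functional assay on DU-145 cells (Homo sapiens) for cytotoxicity, read by MTT assay (on this read-out lower numbers stand for stronger inhibition and higher numbers for weaker inhibition), compound 1 stands lowest of the two numbers. Its nearest neighbour is compound 2, and the step of a 2.3-fold higher number from compound 1 to compound 2 (0.36 log units; beyond the scatter) is the only measured one that bears on the new compound. Compound 3, `COc1ccc2cc([C@H](C)c3nnc(SCc4c(C)cc(C)cc4C)n3-c3ccc(F)cc3)ccc2c1`, differs from compound 1 in one place: 2,4,6-trimethylphenyl in place of 3-methoxyphenyl on a saturated chain carbon bound to a sulfur. The measured step also swapped the 3-methoxyphenyl for a methyl-bearing phenyl on the saturated chain carbon bound to a sulfur, and the number rose modestly. The expectation for compound 3 is therefore a rise of similar size, a 2.0-fold higher number from compound 1 to compound 3 (0.30 log units; within the scatter), rather than no change. Compound 3 is expected to give about 38000 nM in this assay, within a range from 15000 nM to 95000 nM.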

Compound 3, half-maximal inhibitory concentration: 10200 nM
For compound 3 the middle estimate is 3.7-fold (0.57 log units) above the measured one; measured number below the stated range.
By their numbers in this assay, from the lowest: compounds 3 and 1 (each within the scatter of the next); then compound 2.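

Read in this assay, 2,4,6-trimethylphenyl in place of 3-methoxyphenyl on a saturated chain carbon bound to a sulfur gives a 1.9-fold lower number from compound 1 to compound 3 (0.27 log units; within the scatter) and so shows no separation between these two groups at this place. Set against the 4-methylphenyl group, the same 2,4,6-trimethylphenyl group gives a 4.3-fold lower number from compound 2 to compound 3 (0.64 log units; beyond the scatter) and so shows that the earlier rise does not hold for every methyl-bearing phenyl group here. No accompanying data explain this difference between the two methyl-bearing groups.

The compounds shown leave open which of the methyl groups accounts for the step, and a 2,6-dimethylphenyl group would help to separate them. They also leave open whether a carboxylic acid on the phenyl ring, or a longer chain in place of the benzyl group, would keep the number at this level.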